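Amine variation on the thiocarbonyl carbon

The source may report more compounds than this note shows. Statements on the series, on what has been measured and on what is new or still open speak of the compounds shown alone.

Compound 1 `CC1CCCCN1C(=S)SCc1ccc(C(=O)Nc2ccccc2N)cc1` carries 2-methylpiperidin-1-yl on the thiocarbonyl carbon; in a functional assay on A-375 cells (Homo sapiens) for antiproliferative activity, read by CCK-8 assay, with a stated time of 72 h, tested at 8 uM (a higher number here means a stronger effect of the compound at the concentration tested, a lower number a weaker effect), compound 1 gives 85.2%. Compound 2 `CCN(Cc1ccncc1)C(=S)SCc1ccc(C(=O)Nc2ccccc2N)cc1` replaces that group with ethyl((pyridin-4-yl)methyl)amino, and in this assay compound 2 gives 86.2%. The step of a number 1 percentage points higher from compound 1 to compound 2 (within the scatter) shows that exchanging the amine on the thiocarbonyl carbon left the read-out unchanged within the scatter; compound 2 and compound 1 therefore give numbers that cannot be told apart, and no order between the two is read from them.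

Compound 3 `CN(Cc1cccnc1)C(=S)SCc1ccc(C(=O)Nc2ccccc2N)cc1` is the next member: methyl((pyridin-3-yl)methyl)amino in place of ethyl((pyridin-4-yl)methyl)amino on a thiocarbonyl carbon. Going by the values given here, the only measured step that bears on this change is a number 1 percentage points higher from compound 1 to compound 2 (within the scatter), which also swapped the amine on the thiocarbonyl carbon and stayed within the scatter. On that basis the step from compound 2 to compound 3 is expected to be a number 2.2 percentage points lower from compound 2 to compound 3 (within the scatter), with no movement beyond the scatter in either direction.

For compound 3 in this assay the estimate is 84%, with a range from 72% to 94%.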

Compound 3, a percentage reported as inhibition, at one concentration (the size of the read-out at that concentration, not a potency): 83.8%
For compound 3 the middle estimate is 0.2 percentage points above the measured one; measured number inside the range.
By their numbers in this assay, from the lowest: compounds 3, 1 and 2 (each within the scatter of the next).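

In this assay, the change from ethyl((pyridin-4-yl)methyl)amino to methyl((pyridin-3-yl)methyl)amino on the thiocarbonyl carbon gives a number 2.4 percentage points lower from compound 2 to compound 3 (within the scatter) and so alters the chain and the pyridine attachment together without the read-out leaving the scatter. Measured against the saturated 2-methylpiperidin-1-yl, the same group gives a number 1.4 percentage points lower from compound 1 to compound 3 (within the scatter), so the three amines shown, one without an aromatic ring and two with differently attached pyridines, give numbers that cannot be told apart at the single concentration tested. No measured evidence accompanies these numbers to explain why the read-out stays level across the three amines.

Because the ethyl-to-methyl and pyridin-4-yl-to-pyridin-3-yl changes travel together here, the contribution of each remains unresolved, and methyl((pyridin-4-yl)methyl)amino would be the group to separate them. Also open, as far as these compounds go, is whether the level read-out holds for amines further from these three, such as morpholin-4-yl, a long-chain dialkylamino group or a pyridine carrying a carboxylic acid, and whether any difference among the amines would appear in a potency measurement rather than at one concentration.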